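The source may report more compounds than this note shows. Statements on the series, on what has been measured and on what is new or still open speak of the compounds shown alone.

Measured compounds:
Compound 1 `C[C@@H](Cn1ccc(-c2ccc(C#N)c(Cl)c2)n1)NC(=O)c1ccccc1` gives 1830 nM in a functional assay on LNCaP cells (Homo sapiens) for antiproliferative activity, read by CCK-8 assay, with a stated time of 6 days; a lower number here means a stronger inhibitor, a higher number a weaker inhibitor.
Compound 2 `CC(O)c1cccc(C(=O)N[C@@H](C)Cn2ccc(-c3ccc(C#N)c(Cl)c3)n2)c1` gives 2280 nM in this assay.
Compound 3 `CC(O)c1ccc(C(=O)N[C@@H](C)Cn2ccc(-c3ccc(C#N)c(Cl)c3)n2)cc1` gives 3690 nM in this assay.

Compound 2 holds the second highest of the three numbers; its nearest neighbour is compound 1, its furthest compound 3, and the steps of a 1.2-fold higher number from compound 1 to compound 2 (0.10 log units; within the scatter) and a 1.6-fold higher number from compound 2 to compound 3 (0.21 log units; within the scatter) both lie within the scatter, so no order among the three can be claimed.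

Compound 4 `C[C@@H](Cn1ccc(-c2ccc(C#N)c(Cl)c2)n1)NC(=O)c1cccc(OCC(O)CO)c1` differs from compound 2 by one change: 2,3-dihydroxypropoxy in place of 1-hydroxyethyl on an aromatic carbon. Among the compounds with values here, three measured steps bear on this. The steps of a 1.2-fold higher number from compound 1 to compound 2 (0.10 log units; within the scatter) and a 2.0-fold higher number from compound 1 to compound 3 (0.30 log units; within the scatter) show that placing a 1-hydroxyethyl group on the ring of the benzamide, at either position sampled, leaves the number within the scatter, and the step of a 1.6-fold higher number from compound 2 to compound 3 (0.21 log units; within the scatter) shows that moving that group between the two positions also stays within the scatter. The change to compound 4 keeps a hydroxyl-bearing substituent at the same place, meta to a large group, so no step beyond the scatter is expected in this assay in either direction.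

The step of a 1.1-fold higher number from compound 2 to compound 4 (0.04 log units; within the scatter) is what is expected. Compound 4 is therefore estimated at 2500 nM, within a range from 1000 nM to 6500 nM.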

Compound 4, half-maximal inhibitory concentration: 740 nM
Compound 4: middle estimate off by 3.4-fold (0.53 log units), on the high side, outside the stated range (below it).
By their numbers in this assay, from the lowest: compound 4; then compounds 1, 2 and 3 (each within the scatter of the next).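

In this assay, within the data shown here, the 2,3-dihydroxypropoxy group gives a 3.1-fold lower number from compound 2 to compound 4 (0.49 log units; beyond the scatter) and a 2.5-fold lower number from compound 1 to compound 4 (0.39 log units; beyond the scatter), the first steps in this set that lie beyond the scatter. This shows that the number does respond to what is placed on this aromatic carbon, meta to a large group, even though 1-hydroxyethyl there gave only a 1.2-fold higher number from compound 1 to compound 2 (0.10 log units; within the scatter), so carrying a hydroxyl is not enough on its own, with compound 2 standing against any such rule. Nothing given here accounts for the difference between the two groups.

The change from compound 2 to compound 4 alters the chain, its oxygens and its hydroxyls all at once, so these compounds cannot say which of them goes with the lower number, and a simple methoxy group, a 2-hydroxyethoxy chain with one hydroxyl, or a longer chain with more hydroxyls would be needed to separate them. As far as these compounds go, it also remains open whether 2,3-dihydroxypropoxy would give a similar step at the ring position carrying the 1-hydroxyethyl group in compound 3, and whether an amine or a carboxylic acid at the end of the chain would serve as well.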